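Trimming the amide chain from pentyl toward propyl

The source may report more compounds than this note shows. Statements on the series, on what has been measured and on what is new or still open speak of the compounds shown alone.

Compound 1 `C=CC1=C(C(=O)Nc2ccccc2)C(c2ccc(OC)cc2)OC1`: in a functional assay on A549 cells (Homo sapiens) for cytotoxicity, read by MTT assay, with a stated time of 24 h (on this read-out higher numbers stand for weaker inhibition and lower numbers for stronger inhibition), compound 1 gives > 100000 nM, a limit of the assay rather than a number.
Compound 2 `C=CC1=C(C(=O)NCCCCC)C(c2ccc(OC)cc2)OC1`: in this assay compound 2 gives 36500 nM.

For the measured compounds named here, compound 2 thus holds the only plain number in this assay; the other value shown is a limit. Going by the values given here, the single measured step, an at least 2.7-fold lower number from compound 1 to compound 2 (0.43 log units; beyond the scatter), concerns the group on the amide-type nitrogen, and its size is partly shaped by the limit of > 100000 nM in this assay, at which 1 of the 2 values shown sits.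

Compound 3 `C=CC1=C(C(=O)NCCC)C(c2ccc(OC)cc2)OC1` differs from compound 2 by hydrogen in place of ethyl on a saturated chain carbon, three bonds along the chain from an amide-type nitrogen. Among the compounds with values here, no measured step shortens or lengthens this chain on its own; the step from compound 1 to compound 2 exchanges phenyl for pentyl, a different kind of change, so it bears on the present step only loosely. With no closer guide, a step of no more than the usual scatter is expected in this assay. Compound 3 is therefore estimated at 50000 nM, with a range from 18000 nM to 150000 nM. The step this estimate implies, a 1.4-fold higher number from compound 2 to compound 3 (0.14 log units; within the scatter), is expected to stay near the scatter.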

Compound 3, half-maximal inhibitory concentration: > 100000 nM
Compound 3 was reported as a limit; the forecaster's own chance of this, stated with the estimate: 30%; at least 2.0-fold (0.30 log units) between middle value and limit.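

In this assay, removing ethyl from the chain on the amide-type nitrogen, so that pentyl becomes propyl, gives an at least 2.7-fold higher number from compound 2 to compound 3 (0.43 log units; beyond the scatter). The earlier compounds shown here showed only an exchange of phenyl for pentyl, whereas this change alters chain length alone and shows that the read-out responds to that length. Of the three compounds, only compound 2, with its pentyl chain, gives a plain number, so the step can be stated only as a minimum, and the step between the phenyl and propyl amides of compound 1 and compound 3 cannot be read at all, because both values sit at the same boundary: the limit of > 100000 nM in this assay, at which 2 of the 3 values shown sit.

The compounds shown leave open whether butyl on the same nitrogen would read closer to compound 2 or to compound 3, and whether a longer chain such as hexyl or octyl would lower the number further. As far as these compounds go, it also remains open how the read-out would respond to an amine or a carboxylic acid placed at the end of the chain.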